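The source may report more compounds than this note shows. Statements on the series, on what has been measured and on what is new or still open speak of the compounds shown alone.

Compound 1 `CC(C)S(=O)(=O)N1CCC(CN(C2Cc3cc(C#N)ccc3N(Cc3cncn3C)C2)S(=O)(=O)c2ccccn2)CC1`, compound 2 `Cn1cncc1CN1CC(N(CC2CCN(C(=O)c3ccco3)CC2)S(=O)(=O)c2ccccn2)Cc2cc(C#N)ccc21` and compound 3 `Cn1cnc(S(=O)(=O)N2CCC(CN(C3Cc4cc(C#N)ccc4N(Cc4cncn4C)C3)S(=O)(=O)c3ccccn3)CC2)c1` were measured in an ADME assay on Caco-2 cells (Homo sapiens) for permeability, in the apical to basolateral direction; a lower number here means that the compound crosses the layer more slowly, a higher number that the compound crosses the layer faster: compound 1 gives 0.1 10^-6 cm/s, compound 2 gives 0.5 10^-6 cm/s, and compound 3 gives 0.1 10^-6 cm/s.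

Compound 1 thus stands level with compound 3 at the low end of the three: the step of no change at the digits printed from compound 1 to compound 3 (within the scatter) stays within the scatter, while the step of a 5.0-fold higher number from compound 1 to compound 2 (0.70 log units; beyond the scatter) goes beyond it. Compound 4 `CC(C)OC(=O)N1CCC(CN(C2Cc3cc(C#N)ccc3N(Cc3cncn3C)C2)S(=O)(=O)c2ccccn2)CC1` differs from compound 1 by one exchange: isopropoxycarbonyl in place of isopropylsulfonyl on an amine nitrogen in a ring. The step from compound 1 to compound 2 also replaced isopropylsulfonyl on an amine nitrogen in a ring and bears most on this exchange, while the step from compound 1 to compound 3 kept the sulfonyl. A modest rise in this assay is therefore expected. Compound 4 is estimated at 0.3 10^-6 cm/s, between 0.1 10^-6 cm/s and 0.8 10^-6 cm/s, a step of a 3.0-fold higher number from compound 1 to compound 4 (0.48 log units; beyond the scatter).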

Compound 4, apparent permeability: 1 10^-6 cm/s
For compound 4 the middle estimate is 3.3-fold (0.52 log units) below the measured one, outside the stated range (above it).
By their numbers in this assay, from the lowest: compounds 1 and 3 (each within the scatter of the next); then compounds 2 and 4 (each within the scatter of the next).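

With the isopropyl kept, isopropoxycarbonyl in place of isopropylsulfonyl on the amine nitrogen in the ring gives a 10-fold higher number from compound 1 to compound 4 (1.00 log units; beyond the scatter) in this assay, so the rise seen with compound 2 does not depend on its furan-2-yl. The same carbonyl group, set against the (1-methyl-1H-imidazol-4-yl)sulfonyl group, gives a 10-fold higher number from compound 3 to compound 4 (1.00 log units; beyond the scatter) and so stands clear of both sulfonyl compounds. Isopropoxy and furan-2-yl on the carbonyl carbon cannot be told apart, since a 2.0-fold higher number from compound 2 to compound 4 (0.30 log units; within the scatter) stays within the scatter.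

Nothing measured here explains the difference between the carbonyl and sulfonyl groups. Going by these compounds, whether a plain acetyl or a dimethylamine on the carbonyl carbon would match compound 4 remains open.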